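A few compounds are considered here, and "the series" means these few. Any claim that something is new, unique, unknown or untested is made for them only; others in the source may bear on it.

Measured so far in an assay on isolated protein for inhibition of protein deacetylase HDAC6 (Homo sapiens), read by fluorescence, with stated times of 10 min and 2 h; on this read-out lower numbers stand for stronger inhibition and higher numbers for weaker inhibition:
compound 1 `CCCN1CC(=O)N(Cc2ccc(C(=O)NO)cc2)C1=O` — 53.4 nM
compound 2 `O=C(NO)c1ccc(CN2C(=O)CN(Cc3ccccc3)C2=O)cc1` — 12.5 nM

Among the compounds with values here, compound 2 gives the lowest number of the two in this assay; the only step, a 4.3-fold lower number from compound 1 to compound 2 (0.63 log units; beyond the scatter), lies beyond the scatter. Compound 3 `CC(C)(C)c1ccc(CN2CC(=O)N(Cc3ccc(C(=O)NO)cc3)C2=O)cc1` differs from compound 2 by tert-butyl in place of hydrogen on an aromatic carbon. Within the data shown here, no measured step touches that aromatic carbon; the one step available concerns a different place and bears only loosely on this change. The expected change in this assay is therefore set at a 1.4-fold lower number from compound 2 to compound 3 (0.14 log units; within the scatter), within the scatter. Compound 3 is estimated at 9 nM, range 3 nM to 30 nM.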

Compound 3, half-maximal inhibitory concentration: 40.7 nM
Compound 3: middle estimate off by 4.5-fold (0.66 log units), on the low side; the whole stated range lies below it.
By their numbers in this assay, from the lowest: compound 2; then compounds 3 and 1 (each within the scatter of the next).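

In this assay, tert-butyl on the aromatic carbon para to a large group gives a 3.3-fold higher number from compound 2 to compound 3 (0.51 log units; beyond the scatter). Within the data shown here, this is the first reading at this position, and it shows that the position is sensitive to substitution, with this group costing inhibition rather than leaving it unchanged. Nothing available accounts for this loss.

As far as these compounds go, whether the loss belongs to tert-butyl itself or to any group at this place remains open. Methyl, an amine or a carboxylic acid on the same aromatic carbon would bear on that question.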